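This account rests on a few compounds, and the source may have more. Where it says the series, first, only, none or still open, it means among the compounds named here.

Compound 3 `Cc1cc(C(=O)N2CCCCc3ccccc32)ccc1CNC(=O)NCC(N)=O` belongs to a small set built on one shared core. Going by the values given here, in a functional assay on HEK293 cells for agonist activity at Vasopressin V2 receptor (Homo sapiens), read by a luciferase reporter and cAMP accumulation (on this read-out lower numbers stand for an effect already at smaller amounts and higher numbers for an effect only at larger amounts of compound), compound 3 gives 210 nM, the highest of the three numbers measured so far. Compound 2 `Cc1cc(C(=O)N2CCCCc3ccccc32)ccc1CNC(=O)NCC(=O)O` gives 180 nM, and the step of a 1.2-fold higher number from compound 2 to compound 3 (0.07 log units; within the scatter) lies within the scatter. Compound 1 `O=C(NCc1ccc(C(=O)N2CCCCc3ccccc32)c(Cl)c1)Nc1c(F)cccc1F` differs from compound 3 at several places. In this assay, among the compounds with values here, compound 1 gives 40 nM; the gap to compound 3 lies beyond the scatter, but no single step connects the two.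

Compound 4 `Cc1cc(C(=O)N2CCCCc3ccccc32)ccc1CNC(=O)N1CCC[C@H]1C(=O)OC(C)(C)C` has not yet been measured. Relative to compound 3 it carries 2-(tert-butoxycarbonyl)pyrrolidin-1-yl in place of (carbamoylmethyl)amino on a carbonyl carbon. Within the data shown here, the only measured step at this end of the molecule, a 1.2-fold higher number from compound 2 to compound 3 (0.07 log units; within the scatter), was small, yet it swapped one small group for another, whereas the present change is far larger and introduces a ring with a defined stereocentre. Among the measured compounds shown here, no measured step shows what such a change does here. For compound 4 a modest rise in the number, meaning an effect only at larger amounts, is expected, a 1.9-fold higher number from compound 3 to compound 4 (0.28 log units; within the scatter). Compound 4 is therefore estimated at 400 nM, with a likely range from 100 nM to 1600 nM.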

Compound 4, half-maximal effective concentration: 390 nM
Estimate against measurement, compound 4: 1.0-fold (0.01 log units) above; low and high end bracket the measured number.
By their numbers in this assay, from the lowest: compound 1; then compounds 2, 3 and 4 (each within the scatter of the next, the first and the last beyond it).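

At this place on the carbonyl carbon, the shared core carries a much larger group without a clear loss of effect. In this assay, 2-(tert-butoxycarbonyl)pyrrolidin-1-yl in place of (carbamoylmethyl)amino gives a 1.9-fold higher number from compound 3 to compound 4 (0.27 log units; within the scatter) even though it brings a ring, a defined stereocentre and no hydrogen-bond donors. Set against (carboxymethyl)amino, the same group gives a 2.2-fold higher number from compound 2 to compound 4 (0.34 log units; beyond the scatter) as the only step at this place that passes the scatter, and that step is modest. No measurement shown gives a reason for this result. Still open, on these data alone, is which part of the new group matters, and what a pyrrolidine ring bearing a free carboxylic acid instead of the tert-butyl ester would give, or a plain pyrrolidine ring, or the opposite stereocentre.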